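A few compounds are considered here, and "the series" means these few. Any claim that something is new, unique, unknown or untested is made for them only; others in the source may bear on it.

Compound 2, with structure `COc1ccc(F)cc1CNCCCNc1ccnc2cc(Cc3cc(C)cc(C)c3)ccc12`, sits at the low end of the three solubility numbers gathered so far. In a physicochemical assay for solubility, with a stated time of 18 h, at pH 7.4 (on this read-out higher numbers stand for higher solubility and lower numbers for lower solubility), compound 2 gives 4200 nM. Compound 3, with structure `CC(C)CCc1ccc2c(NCCCNCc3ccco3)ccnc2c1`, gives 4200 nM in this assay, a reading level with compound 2 at the digits recorded. Compound 1, with structure `COc1ccccc1Oc1ccc2c(NCCCNCc3ccco3)ccnc2c1`, gives 14500 nM in this assay, the highest of the three numbers.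

Among the compounds with values here, the one single-point step measured so far runs from compound 1 to compound 3: isopentyl in place of 2-methoxyphenoxy on an aromatic carbon, which gave a 3.5-fold lower number from compound 1 to compound 3 (0.54 log units; beyond the scatter). That step bears on compound 4, with structure `COc1ccc(F)cc1CNCCCNc1ccnc2cc(Oc3cccc(N(C)C)c3)ccc12`, since the change from compound 2 to compound 4 is 3-(dimethylamino)phenoxy in place of 3,5-dimethylbenzyl on an aromatic carbon and likewise swaps a carbon-only substituent for an aryl ether bearing a heteroatom on the ring.

Compound 4 is therefore expected to show a higher number than compound 2, estimated as a step of a 2.6-fold higher number from compound 2 to compound 4 (0.42 log units; beyond the scatter), because the reverse swap gave a 3.5-fold lower number from compound 1 to compound 3 (0.54 log units; beyond the scatter) between compound 1 and compound 3. The solubility of compound 4 in this assay is estimated at 11000 nM, with a range from 4500 nM to 27000 nM.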

Compound 4, solubility: 14500 nM
Compound 4: the middle estimate sits 1.3-fold (0.12 log units) below what was measured, within the range that was stated.
By their numbers in this assay, from the lowest: compounds 2 and 3 (each within the scatter of the next); then compounds 1 and 4 (each within the scatter of the next).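

Placing 3-(dimethylamino)phenoxy where 3,5-dimethylbenzyl stood, on the aromatic carbon that is meta to one fused ring and para to the other, gives in this assay a 3.5-fold higher number from compound 2 to compound 4 (0.54 log units; beyond the scatter). Within the data shown here, this is the first reading of a change at this place on the side chain of compound 2, and it runs the same way as the earlier pair, where the aryl ether also carried the higher number: a 3.5-fold lower number from compound 1 to compound 3 (0.54 log units; beyond the scatter). Across these two pairs, the aryl ether goes with the higher number on two different side chains, and neither pair goes against this, but no measurement on hand says what lies behind the difference.

On these data alone, the change from compound 2 to compound 4 alters the linking atom and the ring substituents together, so their separate shares remain open. Plain phenoxy, 3,5-dimethylphenoxy or a 3-(dimethylamino)benzyl group at this place would pull those shares apart.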